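This account rests on a few compounds, and the source may have more. Where it says the series, first, only, none or still open, it means among the compounds named here.

Working notes on the series.

Compound 1 `COc1cc(/C(=C\c2cn(C(C)=O)c3ccc(OCc4ccccc4)cc23)C(=O)O)cc(OC)c1OC` is the weaker of the two compounds measured in a functional assay on A549 cells (Homo sapiens) for cytotoxicity, read by MTT assay, with a stated time of 72 h; on this read-out higher numbers stand for weaker inhibition and lower numbers for stronger inhibition; in this assay compound 1 gives 89100 nM, the highest number of the pair. Among the measured compounds shown here, the only comparator is compound 2 `COc1ccc(Cn2cc(/C=C(/C(=O)O)c3ccccc3)c3cc(OCc4ccccc4)ccc32)cc1`, which in this assay gives 1000 nM; the two structures differ in more than one place, so the gap between them cannot be tied to any single change, and it is noted only that the gap lies beyond the scatter.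

Compound 3 `CC(=O)n1cc(/C=C(/C(=O)O)c2ccc(Cl)cc2)c2cc(OCc3ccccc3)ccc21` is not yet measured. It differs from compound 1 by 4-chlorophenyl in place of 3,4,5-trimethoxyphenyl on a double-bonded chain carbon bound to a carbonyl carbon and a double-bonded chain carbon. For the measured compounds named here, no single-change step is available to anchor this exchange. Going by the values given here, the expectation for compound 3 is a move to a lower number in this assay, of the size an 8.9-fold lower number from compound 1 to compound 3 (0.95 log units; beyond the scatter), partly because compound 2 gives 1000 nM and is the only other compound carrying a plain aryl group at that carbon. Compound 3 is estimated at 10000 nM, with a range from 1500 nM to 60000 nM.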

Compound 3, half-maximal inhibitory concentration: 52300 nM
Compound 3: middle estimate off by 5.2-fold (0.72 log units), on the low side, within the range that was stated.
By their numbers in this assay, from the lowest: compound 2; then compounds 3 and 1 (each within the scatter of the next).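

Among the compounds shown here, the exchange of 3,4,5-trimethoxyphenyl for 4-chlorophenyl on a double-bonded chain carbon bound to a carbonyl carbon and a double-bonded chain carbon gives the first single-change reading at this position: a 1.7-fold lower number from compound 1 to compound 3 (0.23 log units; within the scatter) in this assay. With the acetyl group held constant, the three methoxy groups can therefore be removed and a chlorine introduced without a change that can be told from the scatter, so this assay does not separate these two aryl groups. Nothing measured speaks to why the two aryl groups are not separated.

From the compounds shown here alone, it remains open whether a third aryl group at this carbon, such as 4-aminophenyl, would separate from these two. Going by these compounds, the effect of the acetyl group alone also remains open, as does that of a methyl ester in place of the carboxylic acid.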